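Changing the Side Arm on the Amine Nitrogen

A few compounds are considered here, and "the series" means these few. Any claim that something is new, unique, unknown or untested is made for them only; others in the source may bear on it.

Measured compounds:
compound 1, `N#CC1=C(NCC(=O)N2CCOCC2)N(c2ccccc2)C(=O)N2CCCCC(N3CCCC3)C12`: 69.8%
compound 2, `N#CC1=C(NCC(=O)N2CCCC2)N(c2ccccc2)C(=O)N2CCCCC(N3CCCC3)C12`: 49.8%
compound 3, `COc1ccc(/C=N/C2=C(C#N)C3C(N4CCCC4)CCCCN3C(=O)N2c2ccccc2)cc1`: 71.6%

All three share one core and were tested in a functional assay on the whole organism (strain albino) for inhibition, with Rattus norvegicus as the target, read by paw edema, with stated times of 1 h and 2 h, at a dose of 20 mmol/kg by the intraperitoneal route; a lower number here means less inhibition, a higher number more inhibition at the dose given (going by the name of the read-out). Compound 1 stands second highest of the three. Its nearest neighbour is compound 3: the step of a number 1.8 percentage points higher from compound 1 to compound 3 (within the scatter) is within the scatter, so the two cannot be ordered. Its furthest is compound 2: the step of a number 20 percentage points lower from compound 1 to compound 2 (beyond the scatter) is beyond the scatter, as is the step of a number 21.8 percentage points higher from compound 2 to compound 3 (beyond the scatter).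

Compound 4, `N#CC1=C(NC(=O)c2ccccc2O)N(c2ccccc2)C(=O)N2CCCCC(N3CCCC3)C12`, has not yet been measured. It differs from compound 1 in one place: (2-hydroxyphenyl)carbonyl in place of ((morpholin-4-yl)carbonyl)methyl on an amine nitrogen. Within the data shown here, two measured steps bear on this. The step from compound 1 to compound 3 also replaced the whole side arm with a group carrying a six-membered aromatic ring of carbon only, and gave a step within the scatter. The step from compound 1 to compound 2 changed only the ring in the side arm and gave a modest drop. The change to compound 4 removes the morpholine ring entirely and brings in an aromatic ring with a hydroxyl, which resembles the first step more than the second, so no step beyond the scatter is expected in this assay, with some chance of a modest drop.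

Compound 4 is therefore expected to give 65%, in the range 45% to 82%. That expectation amounts to a step of a number 4.8 percentage points lower from compound 1 to compound 4 (within the scatter), estimated to lie within the scatter.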

Compound 4, a percentage reported as inhibition, in the whole organism at one dose (the size of the read-out at that dose, not a potency): 53.8%
Compound 4: the middle estimate sits 11.2 percentage points above what was measured; measured number inside the range.
By their numbers in this assay, from the lowest: compounds 2 and 4 (each within the scatter of the next); then compounds 1 and 3 (each within the scatter of the next).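

In this assay, the new result shows that bringing a six-membered aromatic ring of carbon onto this amine nitrogen does not by itself hold the number at the level of compound 3. Placing (2-hydroxyphenyl)carbonyl there in place of ((morpholin-4-yl)carbonyl)methyl gives a modest fall (a number 16 percentage points lower from compound 1 to compound 4 (beyond the scatter)), and the comparison with the aromatic arm of compound 3 gives a fall of similar size (a number 17.8 percentage points lower from compound 3 to compound 4 (beyond the scatter)). The arm of compound 4 also cannot be separated from the ((pyrrolidin-1-yl)carbonyl)methyl arm (a number 4 percentage points higher from compound 2 to compound 4 (within the scatter)), so two arms with quite different rings share the lower level, and nothing measured here accounts for these steps.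

The part played by the hydroxyl and the part played by the carbonyl link remain tangled in compound 4, and a plain phenylcarbonyl arm, without the hydroxyl, would be the comparison that pulls them apart. Going by these compounds, it also stays open how an arm ending in a carboxylic acid or an amine, or a longer chain between the amine nitrogen and the morpholine amide, would read out in this whole-animal test.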